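Hydroxyethyl in place of dimethylaminopropyl on a shared core

The source may hold more compounds than are shown below. What is called first, only, known or untested is meant among the compounds shown, and "the series" means these compounds.

Compound 1, `Nc1cccc(Nc2c(C(=O)NCc3ccc(F)cc3)nc(Br)c3cccnc23)c1`: in a functional assay on HCT-116 cells (Homo sapiens) for cytotoxicity, read by MTT assay, with a stated time of 72 h (a lower number here means a stronger inhibitor, a higher number a weaker inhibitor), compound 1 gives only a limit, > 10000 nM.
Compound 2, `C[C@@H](Nc1c(C(=O)NCc2ccc(F)cc2)nc(Br)c2cccnc12)c1ccccc1`: in this assay compound 2 gives only a limit, > 20000 nM.
Compound 3, `CN(C)CCCNc1c(C(=O)NCc2ccc(F)cc2)nc(Br)c2cccnc12`: in this assay compound 3 gives only a limit, > 10000 nM.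

All three measured compounds share one core and differ only in the group on the nitrogen on the aromatic ring. None of them yields a number: two sit at the limit of > 10000 nM in this assay, at which 2 of the 3 values shown sit, one at the limit of > 20000 nM in this assay, at which 1 of the 3 values shown sits. Going by these compounds, the steps among them are therefore not readable: a step that the two limits leave unreadable from compound 1 to compound 2, a step that the two limits leave unreadable from compound 1 to compound 3 and a step that the two limits leave unreadable from compound 2 to compound 3 all remain open, since each end is a limit.

Compound 4, `O=C(NCc1ccc(F)cc1)c1nc(Br)c2cccnc2c1NCCO`, carries a smaller side chain. The change from compound 3 is hydroxy in place of (dimethylamino)methyl on a saturated chain carbon, two bonds along the chain from a nitrogen on an aromatic ring. Because compound 3 gives > 10000 nM and because the neighbouring compounds also stop at limits, the measured steps give no size and no direction that would bear on this change; a strong inhibitor would be a departure from everything seen so far. Compound 4 is therefore expected to stay near the limits of its three relatives. The expected step that the limit leaves unreadable from compound 3 to compound 4 is essentially none beyond the scatter. Compound 4 is estimated at 15000 nM, within 5000 nM to 40000 nM.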

Compound 4, half-maximal inhibitory concentration: > 20000 nM
Compound 4 gave a limit, no number; the forecaster's own chance of this, stated with the estimate: 80%; at least 1.3-fold (0.12 log units) between middle value and limit.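

In this assay compound 4 gives only a limit, > 20000 nM. The steps from compound 1, compound 2 and compound 3 to compound 4 cannot be read: all four compounds stop at limits. The compounds shown leave open how large any of these steps is, and whether any group on this nitrogen gives a measurable value in this assay.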